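This account rests on a few compounds, and the source may have more. Where it says the series, first, only, none or still open, it means among the compounds named here.

Compound 1 `COC(=O)c1cc(-c2cccc(NC(=O)c3ccc(/C=C/C(=O)c4ccccc4)cc3)c2)on1` — in an ADME assay on Vero cells (Chlorocebus sabaeus) for cytotoxicity, read by MTT assay, with a stated time of 72 h (a higher number here means that more compound is tolerated, a lower number that less compound is tolerated), compound 1 gives > 50 ug/mL, which is a limit of the assay.
Compound 2 `COC(=O)c1cc(-c2cccc(NC(=O)c3ccc(/C=C/C(=O)c4ccccc4Br)cc3)c2)on1` — in this assay compound 2 gives > 40 ug/mL, which is also a limit of the assay.

Compound 2 therefore stands only at a limit on the numbers shown, and the one other value shown, that of compound 1, is a limit as well. Among the measured compounds shown here, the step that the two limits leave unreadable from compound 1 to compound 2 is the only measured step, and its size cannot be read because the limit of > 40 ug/mL in this assay, at which 1 of the 2 values shown sits, and the limit of > 50 ug/mL in this assay, at which 1 of the 2 values shown sits, are where the two values sit.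

Compound 3 `CCOc1ccc(C(=O)/C=C/c2ccc(C(=O)Nc3cccc(-c4cc(C(=O)OC)no4)c3)cc2)cc1` differs from compound 2 by 4-ethoxyphenyl in place of 2-bromophenyl on a carbonyl carbon. This change touches the same ring on the carbonyl carbon that the measured step altered, so that step is the one that bears on it, but it offers no readable size. Neither value shown reached a measurable number, so no step beyond the scatter is expected from compound 2 to compound 3, and the expected step is a step that the limit leaves unreadable from compound 2 to compound 3. Compound 3 is accordingly estimated at 60 ug/mL in this assay, within a range of 30 ug/mL to 120 ug/mL, most likely reported once more as a limit.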

Compound 3, half-maximal cytotoxic concentration: > 40 ug/mL
Compound 3 gave a limit, no number; the forecaster's own chance of this, stated with the estimate: 75%; the middle value does not contradict the limit.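

Compound 3, like compound 1 and compound 2, gives only a limit in this assay and not a number, so none of the steps among the three can be read: the limit of > 40 ug/mL in this assay, at which 2 of the 3 values shown sit.

The compounds shown leave open what concentration of any of the three is actually tolerated in this assay and whether 2-bromophenyl or 4-ethoxyphenyl on the carbonyl carbon changes it at all.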